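The source may hold more compounds than are shown below. What is called first, only, known or untested is meant among the compounds shown, and "the series" means these compounds.

Going by the values given here, in a functional assay on HCT-116 cells (Homo sapiens) for antiproliferative activity, read by sulforhodamine B assay, with a stated time of 72 h (a lower number here means a stronger inhibitor, a higher number a weaker inhibitor), compound 1 `COc1ncc(-c2ccc3ncnc(Nc4cnn(CCC(=O)O)c4)c3c2)cc1NS(C)(=O)=O` gives 1290 nM, the only actual number so far. Compound 2 `CCCCS(=O)(=O)Nc1cc(-c2ccc3ncnc(Nc4ccc(OCCO)nc4)c3c2)cnc1OC` gives > 20000 nM, which is a limit of the assay and not a number. Compound 3 `COc1ncc(-c2ccc3ncnc(Nc4ccc(OCCO)cc4)c3c2)cc1NS(C)(=O)=O` keeps the core of compound 1 and changes one group: 4-(2-hydroxyethoxy)phenyl in place of 1-(2-carboxyethyl)-1H-pyrazol-4-yl on a nitrogen on an aromatic ring. It carries 4-(2-hydroxyethoxy)phenyl in place of 1-(2-carboxyethyl)-1H-pyrazol-4-yl on a nitrogen on an aromatic ring. With so little measured, no shift beyond the usual scatter is expected in either direction, and the estimated step is a 1.2-fold higher number from compound 1 to compound 3 (0.07 log units; within the scatter). For compound 3 the expected value is 1500 nM, within an estimated range of 200 nM to 12000 nM.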

Compound 3, half-maximal inhibitory concentration: 4860 nM
Compound 3: the middle estimate sits 3.2-fold (0.51 log units) below what was measured; low and high end bracket the measured number.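

At this place, on a nitrogen on an aromatic ring, the choice of group shifts the result in this assay: 4-(2-hydroxyethoxy)phenyl in place of 1-(2-carboxyethyl)-1H-pyrazol-4-yl gives a 3.8-fold higher number from compound 1 to compound 3 (0.58 log units; beyond the scatter), a modest step and the first that can be read here. The ring and the chain on it change together, so the step cannot be assigned to either one alone. Nothing measured here accounts for the step. Open, going by these compounds, is what the pyrazole ring would give with the hydroxyethoxy chain, or the phenyl ring with a carboxylic acid chain. On these data alone, an amine at the end of the chain also remains open.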